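The source may report more compounds than this note shows. Statements on the series, on what has been measured and on what is new or still open speak of the compounds shown alone.

Two compounds have been measured in an assay on isolated protein for inhibition of Amine oxidase [flavin-containing] A (Homo sapiens), read by fluorescence; a lower number here means a stronger inhibitor, a higher number a weaker inhibitor:

Compound 1 `COc1cccc(-c2csc(N/N=C/c3ccco3)n2)c1`: 343 nM
Compound 2 `COc1cccc(-c2csc(N/N=C3\CCC(C)C3)n2)c1`: 1450 nM

Compound 2 holds the highest of the two numbers in this assay; its nearest neighbour is compound 1, and the step of a 4.2-fold higher number from compound 1 to compound 2 (0.63 log units; beyond the scatter) lies beyond the scatter. That single step is the only one on record, and it describes the exchange on the nitrogen attached to the shared core of a five-membered aromatic ring with one hetero atom for a five-membered non-aromatic carbon ring, which raised the number.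

Compound 3 `COc1cccc(-c2csc(N/N=C/c3cccs3)n2)c1` is not yet measured. The change from compound 2 to compound 3 is a group of 7 heavy atoms (5 carbon, 1 nitrogen, 1 sulfur; one five-membered aromatic ring with 1 hetero atom) in place of a group of 7 heavy atoms (6 carbon, 1 nitrogen; one five-membered non-aromatic ring of carbon only), on a nitrogen on an aromatic ring. This change runs in the opposite direction to the recorded step: a five-membered aromatic ring with one hetero atom returns in place of the non-aromatic carbon ring, though the hetero atom is now sulfur rather than oxygen. Because a 4.2-fold higher number from compound 1 to compound 2 (0.63 log units; beyond the scatter) was modest but beyond the scatter, the step is expected to reverse most of it, and a lower number is expected for compound 3, roughly a 3.6-fold lower number from compound 2 to compound 3 (0.56 log units; beyond the scatter). Compound 3 is therefore estimated at 400 nM in this assay, with a likely range from 150 nM to 1100 nM.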

Compound 3, half-maximal inhibitory concentration: 458 nM
Compound 3: the middle estimate sits 1.1-fold (0.06 log units) below what was measured; the range from low to high includes it.
By their numbers in this assay, from the lowest: compounds 1 and 3 (each within the scatter of the next); then compound 2.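

In this assay, thiophen-2-yl in place of furan-2-yl on a carbon with a double bond to nitrogen gave a step within the scatter (a 1.3-fold higher number from compound 1 to compound 3 (0.13 log units; within the scatter)), so at this position the two aromatic rings could not be told apart by this read-out. Going back from the five-membered non-aromatic ring of carbon only to a five-membered aromatic ring with one hetero atom gave a step beyond the scatter (a 3.2-fold lower number from compound 2 to compound 3 (0.50 log units; beyond the scatter)). The earlier step now has a second aromatic partner, and among these three compounds, compound 2 with its carbon ring stands apart from both compound 1 and compound 3, while nothing on hand accounts for either step.

The compounds shown leave open whether a six-membered aromatic ring such as phenyl or pyridin-2-yl, or an open carbon chain such as a butyl group, would read like the two aromatic rings or like the carbon ring. They also leave open how an amine or a carboxylic acid on the thiophen-2-yl ring would change the number, and whether any change elsewhere on the shared core would alter what this position shows.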